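The compounds below may be only part of what the source reports. "The series", "measured", "known", "first", "only" and "open" are said of these compounds alone.

Measured compounds:
- compound 1, `Clc1ccccc1Cn1nnc2c(NC3CCCCC3)nc(-c3ccccc3)nc21`, 34000000 nM in an assay on isolated protein for binding affinity to adenosine receptor A1 (Bos taurus); a lower number here means a stronger inhibitor, a higher number a weaker inhibitor
- compound 2, `OC1CCC(Nc2nc(-c3ccccc3)nc3c2nnn3Cc2ccccc2Cl)CC1`, 3100000 nM in this assay

Both numbers are very high, so both compounds bind only weakly in this assay. Going by the values given here, compound 2 stands at the lower of the two numbers; the only other compound, compound 1, sits an 11-fold lower number from compound 1 to compound 2 (1.04 log units; beyond the scatter) away. Among the compounds with values here, that single step, the introduction of a hydroxy on the saturated ring, is the whole of what has been measured so far.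

The next compound, compound 3, `COc1ccc(C(=O)Nc2nc(-c3ccccc3)nc3c2nnn3Cc2ccccc2Cl)cc1`, is not yet measured. It differs from compound 2 by (4-methoxyphenyl)carbonyl in place of 4-hydroxycyclohexyl on a nitrogen on an aromatic ring. Within the data shown here, only one measured step bears on this change, and only in part: an 11-fold lower number from compound 1 to compound 2 (1.04 log units; beyond the scatter) shows that the hydroxy group that now leaves carried a large part of what little binding compound 2 has. Among the measured compounds shown here, the amide that enters has no measured precedent here, and nothing in the data says whether it can make up for the loss. The working expectation is therefore a number higher than that of compound 2, roughly back toward the level of compound 1, with wide uncertainty: the step from compound 2 to compound 3 is estimated as a 4.8-fold higher number from compound 2 to compound 3 (0.68 log units; beyond the scatter). For compound 3 in this assay the estimate is 15000000 nM, with a range from 1500000 nM to 150000000 nM.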

Compound 3, inhibition constant: 20000000 nM
Beside the measured number, compound 3's estimate is 1.3-fold (0.12 log units) below it; measured number inside the range.
By their numbers in this assay, from the lowest: compound 2; then compounds 3 and 1 (each within the scatter of the next).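

In this assay, the (4-methoxyphenyl)carbonyl group on the nitrogen does not keep what the hydroxy added in an 11-fold lower number from compound 1 to compound 2 (1.04 log units; beyond the scatter): replacing 4-hydroxycyclohexyl with it gives a 6.5-fold higher number from compound 2 to compound 3 (0.81 log units; beyond the scatter). Set against the plain cyclohexyl, the same group gives a 1.7-fold lower number from compound 1 to compound 3 (0.23 log units; within the scatter), so an aromatic ring joined through a carbonyl and a saturated carbon ring without hydroxy cannot be told apart at this position, even though the two groups differ in ring type and in the amide carbonyl. Among the three compounds, only compound 2, the one carrying the hydroxy on a saturated ring, stands apart from the others, and no measurement at hand accounts for either new step.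

From the compounds shown here alone, it remains open whether the lower number of compound 2 depends on the hydroxy alone or on the hydroxy together with the saturated ring; an amine or a carboxylic acid at the same place on the cyclohexyl ring would test this. Going by these compounds, it is also open whether the methoxy or the carbonyl matters in compound 3, which an unsubstituted benzoyl group or a 4-hydroxyphenyl group on the nitrogen would help to separate.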